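A few compounds are considered here, and "the series" means these few. Any claim that something is new, unique, unknown or untested is made for them only; others in the source may bear on it.

Three compounds sharing one core were tested in a functional assay on cells (Rhabdomyosarcoma cell, Homo sapiens) for cytotoxicity; a lower number here means a stronger inhibitor, a higher number a weaker inhibitor. Compound 1 `Cc1ccsc1C(c1ccccc1)N1CCN(c2ncnc3c2cnn3-c2ccccc2)CC1` gives only a limit there, > 25000 nM. Compound 2 `c1ccc(C(c2ccco2)N2CCN(c3ncnc4c3cnn4-c3ccccc3)CC2)cc1` likewise returns a limit, > 25000 nM. Compound 3 `c1ccc(C(c2ccccc2)N2CCN(c3ncnc4c3cnn4-c3ccccc3)CC2)cc1` also sits at a limit, > 25000 nM. The steps among them, a step that the two limits leave unreadable from compound 1 to compound 2, a step that the two limits leave unreadable from compound 1 to compound 3 and a step that the two limits leave unreadable from compound 2 to compound 3, are therefore not readable, and the only fixed point is the limit of > 25000 nM in this assay, at which 3 of the 3 values shown sit. Compound 4 `Brc1ccc(C(c2ccccc2)N2CCN(c3ncnc4c3cnn4-c3ccccc3)CC2)cc1` differs from compound 3 by bromo in place of hydrogen on an aromatic carbon. Going by the values given here, no measured step bears on this change; the three earlier swaps left every value at the limit, so no step beyond the scatter is expected. Compound 4 is estimated at 40000 nM, within 10000 nM to 200000 nM, which means an expected step that the limit leaves unreadable from compound 3 to compound 4 and most likely another limit.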

Compound 4, half-maximal inhibitory concentration: > 25000 nM
Compound 4 ended at the assay's limit; the forecaster's own chance of this, stated with the estimate: 75%; the middle value is on the limit's open side.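

Compound 4 joins compound 1, compound 2 and compound 3 at a limit, so no step among these compounds can be read: the limit of > 25000 nM in this assay, at which 4 of the 4 values shown sit. The compounds shown leave open which change to the shared structure, if any, would give a measurable number rather than a limit in this assay.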